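The source may hold more compounds than are shown below. What is called first, only, known or untested is meant among the compounds shown, and "the series" means these compounds.

Measured compounds in a functional assay on HOP-92 cells (Homo sapiens) for inhibition, read by sulforhodamine B assay, with a stated time of 48 h; a lower number here means a stronger inhibitor of growth, a higher number a weaker inhibitor of growth:
compound 1 `COc1ccc2[nH]c(-c3ccccc3)c(C=C(C#N)C#N)c2c1`, compound 1 gives 2400 nM;
compound 2 `COc1ccc(-c2[nH]c3ccc(OC)cc3c2C=C(C#N)C#N)cc1`, compound 2 gives 23000 nM;
compound 3 `COc1ccc2[nH]c(-c3ccccc3)c(/C=C(\C#N)S(=O)(=O)c3ccccc3)c2c1`, compound 3 gives 6100 nM.

Between compound 2 and compound 1 the change is hydrogen in place of methoxy on an aromatic carbon, and it gave a 9.6-fold lower number from compound 2 to compound 1 (0.98 log units; beyond the scatter). Compound 4 `N#C/C(=C\c1c(-c2ccccc2)[nH]c2ccccc12)S(=O)(=O)c1ccccc1` is not yet measured; it differs from compound 3 by hydrogen in place of methoxy on an aromatic carbon. The difference between the core of compound 3 and the core of compound 2 is not broken down here.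

The change from compound 3 to compound 4 is the same kind of change as that from compound 2 to compound 1, but not the same: in the earlier pair the place is para to a large group, in the new pair it is part of a fused or bridged system of two rings, meta to a fused ring and para to a fused ring. One prior step at a different place is a thin basis, so a smaller step, a 2.0-fold lower number from compound 3 to compound 4 (0.31 log units; beyond the scatter), is expected. Compound 4 is estimated at 3000 nM in this assay, within 1000 nM to 9000 nM.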

Compound 4, concentration for 50% growth inhibition: 10300 nM
The estimate for compound 4 lay 3.4-fold (0.54 log units) below the measured number; measured number above the stated range.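

In this assay hydrogen in place of methoxy on the fused system gives a 1.7-fold higher number from compound 3 to compound 4 (0.23 log units; within the scatter) and so does not repeat the drop in number seen on the other core. In these compounds, the effect of this change does not carry from one core to the other: the same change on two cores in this assay, a 9.6-fold lower number (0.98 log units; beyond the scatter) from compound 2 to compound 1 and a 1.7-fold higher number (0.23 log units; within the scatter) from compound 3 to compound 4, 16-fold (1.21 log units) apart, beyond the scatter of two such steps.
The two pairs also differ in the place of the change, and the data do not separate place from core as the source of the gap; two pairs set no rule for the series.

Still open, as far as these compounds go, is how the change behaves at one and the same place on both cores. Also open, from the compounds shown here alone, is what an amine or a longer alkoxy chain would give in place of the methoxy.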